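Replacing the Imidazolyl Group with Trifluoromethyl: Expecting Little Change

The compounds below may be only part of what the source reports. "The series", "measured", "known", "first", "only" and "open" are said of these compounds alone.

Compound 1, `Cc1cc(OC2CCCC2)c(S(C)(=O)=O)cc1C(=O)N=C(N)N`, in a functional assay for inhibition of sodium/hydrogen exchanger (Oryctolagus cuniculus); a higher number here means a weaker inhibitor, a lower number a stronger inhibitor: 27 nM
Compound 2, `Cc1cn(-c2cc(C)c(C(=O)N=C(N)N)cc2S(C)(=O)=O)cn1`, in this assay: 28 nM

For the measured compounds named here, compound 2 has the higher of the two numbers, but its nearest neighbour is compound 1, and the only measured step, a 1.0-fold higher number from compound 1 to compound 2 (0.02 log units; within the scatter), lies within the scatter. So the two compounds cannot be told apart in this assay. That step exchanged one group for another at the same position of the shared core, and the number did not move.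

Compound 3, `Cc1cc(C(F)(F)F)c(S(C)(=O)=O)cc1C(=O)N=C(N)N`, is the next compound. It differs from compound 2 in one place: trifluoromethyl in place of 4-methyl-1H-imidazol-1-yl on an aromatic carbon. Going by the values given here, the one step on record bears on this change only in that it touched the same position; it was flat, and a second, quite different group there gave the same read-out as the first. Among the compounds with values here, no measured step shows that this position drives the number, so the expectation is no change beyond the scatter, with the estimated step of a 1.1-fold higher number from compound 2 to compound 3 (0.03 log units; within the scatter). For compound 3 the expected value in this assay is 30 nM, within the range 10 nM to 90 nM.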

Compound 3, half-maximal inhibitory concentration: 37 nM
Estimate against measurement, compound 3: 1.2-fold (0.09 log units) below; low and high end bracket the measured number.
By their numbers in this assay, from the lowest: compounds 1, 2 and 3 (each within the scatter of the next).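

Trifluoromethyl is the third group seen at this position, ortho to a methylsulfonyl group, and in this assay the two new comparisons are a 1.3-fold higher number from compound 2 to compound 3 (0.12 log units; within the scatter) and a 1.4-fold higher number from compound 1 to compound 3 (0.14 log units; within the scatter). The earlier step compared only two groups that both contain a ring, whereas trifluoromethyl has no ring and no hydrogen-bond acceptors, unlike the 4-methyl-1H-imidazol-1-yl group it replaces, so neither that ring nor those acceptors are shown to be needed for this read-out in these compounds. No measurement of another kind is available to bear on this result.

Going by these compounds, whether the number would also stay within the scatter with a very different group at this position, such as an amine, a carboxylic acid or a longer alkyl chain, remains open. The methyl group and the methylsulfonyl group stay the same in all three compounds, so what either of them contributes to the number is also unknown.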